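The source may report more compounds than this note shows. Statements on the series, on what has been measured and on what is new or still open speak of the compounds shown alone.

Compound 1, `O=C1C=C(NCc2ccccc2)C(=O)c2c1nc1n2[C@H]2OC[C@@H](O)[C@H]2OC1`: in a functional assay on MCF7 cells (Homo sapiens) for inhibition, read by sulforhodamine B assay (on this read-out higher numbers stand for weaker inhibition and lower numbers for stronger inhibition), compound 1 gives > 8000 nM, which is a limit of the assay and not a number.
Compound 2, `COc1cccc(NC2=CC(=O)c3nc4n(c3C2=O)[C@H]2OC[C@@H](O)[C@H]2OC4)c1`: compound 2 gives > 4000 nM, again a limit rather than a number.
Compound 3, `CCc1ccc(NC2=CC(=O)c3nc4n(c3C2=O)[C@H]2OC[C@@H](O)[C@H]2OC4)cc1`: compound 3 gives 960 nM.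

Within the data shown here, compound 3 therefore stands as the only compound of the three with an actual number; the other two sit at limits. Two measured steps lead to it: an at least 8.3-fold lower number from compound 1 to compound 3 (0.92 log units; beyond the scatter) and an at least 4.1-fold lower number from compound 2 to compound 3 (0.61 log units; beyond the scatter). The step between the two limits, a step that the two limits leave unreadable from compound 1 to compound 2, cannot be read.

Compound 4, `O=C1C=C(NC2CCCC2)C(=O)c2c1nc1n2[C@H]2OC[C@@H](O)[C@H]2OC1`, differs from compound 3 by cyclopentyl in place of 4-ethylphenyl on an amine nitrogen. Among the measured compounds shown here, none of the measured steps exchanges the aromatic ring on the amine nitrogen for a saturated one, so they bear on this change only loosely: they show that of three substituents on that nitrogen, only 4-ethylphenyl reaches a number, while benzyl and 3-methoxyphenyl do not. Compound 4 is therefore expected to give a weaker result, with a step of a 5.2-fold higher number from compound 3 to compound 4 (0.72 log units; beyond the scatter) in this assay, and it may well fall back to a limit. The estimate for compound 4 is 5000 nM, with a range from 1500 nM to 20000 nM.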

Compound 4, half-maximal inhibitory concentration: > 16000 nM
Compound 4: no number, only a limit; the forecaster's own chance of this, stated with the estimate: 50%; middle value at least 3.2-fold (0.50 log units) away from the limit.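

In this assay, cyclopentyl in place of 4-ethylphenyl on the amine nitrogen gives an at least 16-fold higher number from compound 3 to compound 4 (1.22 log units; beyond the scatter), the only exchange of an aromatic ring for a saturated ring among the compounds shown. Compound 4 gives a limit of the assay and not a number: the limit of > 16000 nM in this assay, at which 1 of the 4 values shown sits. So 4-ethylphenyl remains the only one of the four substituents on this nitrogen that reaches a number, and the steps from compound 1 and compound 2 to compound 4 cannot be read, since both ends of each are limits.

The compounds shown leave open whether the number depends on the aromatic ring itself or on its ethyl group, which an unsubstituted phenyl or a 4-methylphenyl would separate. They also leave open how an open chain such as n-pentyl, or a cyclohexyl ring, would behave on this nitrogen.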